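Inverting One Stereocentre: From Compound 2 to Compound 3

A few compounds are considered here, and "the series" means these few. Any claim that something is new, unique, unknown or untested is made for them only; others in the source may bear on it.

Compound 1, `O=C([C@@H]1C[C@@H]1F)N1CC2CC(C1)N2`: 110%
Compound 2, `C[C@H]1C[C@H]1C(=O)N1CC2CC(C1)N2`: 93%

In an assay on SH-EP1 cells for agonist activity at Neuronal acetylcholine receptor; alpha4/beta2 (Homo sapiens), read by FLIPR and calcium flux (a lower number here means a smaller maximal response, a higher number a larger maximal response), compound 2 gives 93%, the lowest of the two numbers shown. Among the measured compounds shown here, its nearest neighbour is compound 1, reached by the single measured step, a number 17 percentage points lower from compound 1 to compound 2 (beyond the scatter), in which methyl takes the place of fluoro on a saturated ring carbon. Compound 3, `C[C@H]1C[C@@H]1C(=O)N1CC2CC(C1)N2`, differs from compound 2 as follows: the two compounds have the same atoms and bonds; at least one stereo element is drawn with a configuration in one of them and without one in the other: 1 of 4 stereo elements differ; a stereocentre at a saturated ring carbon is drawn R in compound 2 and S in compound 3. For the measured compounds named here, no measured step covers an inversion of configuration alone, so the fluoro-to-methyl step offers no direct guide, and the direction of any change is open. The step is expected to be a number 3 percentage points lower from compound 2 to compound 3 (within the scatter), small relative to the scatter. Compound 3 is accordingly estimated at 90%, within 65% to 115%.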

Compound 3, largest response reached (Emax), in percent of the reference or control that the assay uses: 85%
For compound 3 the middle estimate is 5 percentage points above the measured one, within the range that was stated.
By their numbers in this assay, from the lowest: compounds 3 and 2 (each within the scatter of the next); then compound 1.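

In this assay, the inversion at this saturated ring carbon gives a number 8 percentage points lower from compound 2 to compound 3 (within the scatter), so the two methyl compounds cannot be told apart by their response. Replacing 2-fluorocyclopropyl with 2-methylcyclopropyl still registers with this configuration, at a number 25 percentage points lower from compound 1 to compound 3 (beyond the scatter). The inversion comparison carries one caveat: the fact that one of compounds 2 and 3 is drawn with a defined configuration and the other without, at the place where they differ.

Going by these compounds, whether an ethyl group or an amine in place of the methyl would keep this response remains open. So does whether the same inversion in compound 1 would prove equally small.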